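This account rests on a few compounds, and the source may have more. Where it says the series, first, only, none or still open, it means among the compounds named here.

Three compounds carrying the same dienamide core, capped by a piperidine amide, have been tested in an assay for inhibition of Polyunsaturated fatty acid 5-lipoxygenase (Homo sapiens), read by spectrophotometry, tested at 20 uM; a higher number here means more inhibition at the concentration tested (going by the name of the read-out), a lower number less inhibition. Compound 1 `COc1cc(OC)c(/C=C/C=C/C(=O)N2CCCCC2)c(OC)c1` carries three methoxy groups on its aromatic ring and in this assay gives 77.1%. Compound 3 `COc1cc(/C=C/C=C/C(=O)N2CCCCC2)cc(OC)c1` carries two methoxy groups and in this assay gives 64.9%. Compound 2 `O=C(/C=C/C=C/c1ccc(OC2CCCC2)cc1)N1CCCCC1` carries a cyclopentyloxy group instead and in this assay gives 16.1%, the lowest of the three numbers; the gap to compound 3 and the larger gap to compound 1 both lie beyond the usual scatter of such measurements, so compound 2 clearly gives the lowest inhibition in this assay among them at the concentration tested.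

Compound 4 `CC(=O)Oc1ccc(/C=C/C=C/C(=O)N2CCCCC2)cc1` has not yet been measured. It differs from compound 2 in one place: acetyl in place of cyclopentyl on an oxygen on an aromatic ring. Within the data shown here, no measured pair in this set shares exactly this change, so there is no directly comparable step to lean on.

What the set does show is that compounds with small oxygen substituents on the aromatic ring, compound 1 and compound 3, give more inhibition than compound 2 with its cyclopentyl group. On that basis, a moderate rise is expected in this assay for compound 4, with a step of a number 18.9 percentage points higher from compound 2 to compound 4 (beyond the scatter) estimated. Compound 4 is accordingly estimated to reach 35%, with a plausible range of 12% to 62%.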

Compound 4, a percentage reported as inhibition, at one concentration (the size of the read-out at that concentration, not a potency): 18.3%
For compound 4 the middle estimate is 16.7 percentage points above the measured one; low and high end bracket the measured number.
By their numbers in this assay, from the lowest: compounds 2 and 4 (each within the scatter of the next); then compound 3; then compound 1.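

In this assay, putting acetyl in place of cyclopentyl on an oxygen on an aromatic ring gives a number 2.2 percentage points higher from compound 2 to compound 4 (within the scatter), so the two compounds cannot be told apart at the concentration tested. Among these compounds, this is the first direct comparison at this position: a five-membered carbon ring with no hydrogen-bond acceptor and a smaller acetyl group with one hydrogen-bond acceptor give readings that lie within the scatter of each other. The earlier compounds shown here differ from compound 2 in more than one place and could not show this, and the new pair gives no sign that the low reading of compound 2 depends on the cyclopentyl ring itself. Nothing measured here explains why this pair reads alike.

Still open, as far as these compounds go, is whether any group on this oxygen can shift the reading, for instance a longer chain ending in an amine or a carboxylic acid. Also open, from the compounds shown here alone, is how the methoxy groups of compound 1 and compound 3 relate to this pair, as a single methoxy group on this oxygen would be one change away from both compound 2 and compound 4.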